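Nitro in Place of Hydrogen on the Benzoyl Ring

The compounds below may be only part of what the source reports. "The series", "measured", "known", "first", "only" and "open" are said of these compounds alone.

Measured so far:
- Compound 1 `CC1(C)C=C(n2ccccc2=O)c2cc(C(=O)c3ccccc3)ccc2O1` gives 6.61 in a functional assay (aorta) with Rattus norvegicus as the target; on this read-out higher numbers stand for higher potency (the scale is a negative logarithm) and lower numbers for lower potency.
- Compound 2 `COc1ccc(C(=O)c2ccc3c(c2)C(n2ccccc2=O)=CC(C)(C)O3)cc1` gives 6.15 in this assay.
- Compound 3 `CC1(C)C=C(n2ccccc2=O)c2cc(C(=O)c3ccc(O)cc3)ccc2O1` gives 6.65 in this assay.

Among these three, compound 1 and compound 3 lie within the scatter of each other, as the step of a number 0.04 log units higher from compound 1 to compound 3 (within the scatter) shows, while compound 2 sits clearly lower, as the step of a number 0.46 log units lower from compound 1 to compound 2 (beyond the scatter) shows. The third step, a number 0.50 log units higher from compound 2 to compound 3 (beyond the scatter), shows that trading the methyl on the aromatic oxygen for hydrogen recovers that loss.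

The new compound, compound 4 `CC1(C)C=C(n2ccccc2=O)c2cc(C(=O)c3ccccc3[N+](=O)[O-])ccc2O1`, differs from compound 1 by nitro in place of hydrogen on an aromatic carbon. For the measured compounds named here, no measured step puts a nitro group, or any group ortho to a large group, on this ring, so the measured steps bear on it only loosely: a hydroxy there cost nothing, a methoxy cost a modest amount. Going by the values given here, a nitro seems more likely to behave like the methoxy than like the hydroxy, but with no direct precedent the expectation stays wide. The step of a number 0.31 log units lower from compound 1 to compound 4 (beyond the scatter) is therefore expected to be small and downward, and compound 4 is estimated at 6.3, within a range from 5.7 to 6.9.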

Compound 4, logarithm of the reciprocal of the active concentration, log(1/C): 6.17
Beside the measured number, compound 4's estimate is 0.13 log units above it; the measured number falls inside the stated range.
By their numbers in this assay, from the lowest: compounds 2 and 4 (each within the scatter of the next); then compounds 1 and 3 (each within the scatter of the next).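

In this assay, for the compounds shown here, the change from phenyl to 2-nitrophenyl, which puts a nitro on an aromatic carbon ortho to a large group, gives a number 0.44 log units lower from compound 1 to compound 4 (beyond the scatter) and so costs a modest amount of potency at a place on this ring that the earlier compounds left empty. Exchanging the whole aryl group gives a number 0.48 log units lower from compound 3 to compound 4 (beyond the scatter) when 2-nitrophenyl replaces 4-hydroxyphenyl, but a number 0.02 log units higher from compound 2 to compound 4 (within the scatter) when it replaces 4-methoxyphenyl, so this assay cannot tell compound 2 and compound 4 apart even though their groups differ in both kind and place. Nothing measured here explains the drop, and no separate data on the nitro group accompany these numbers.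

On these data alone, the two aryl exchanges alter the group and its place together, so it stays open whether the modest loss in compound 4 belongs to the nitro itself or to its place ortho to a large group. As far as these compounds go, whether a smaller group such as a methyl, or an amine or a carboxylic acid, would be tolerated at that same place also remains unknown.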